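The source may hold more compounds than are shown below. What is called first, only, known or untested is meant among the compounds shown, and "the series" means these compounds.

Measured compounds:
compound 1 `CSC1(C)C(=O)N(c2ccccc2)c2ncccc21`: 53%
compound 2 `COCCSC1(C)C(=O)N(c2ccccc2)c2ncccc21`: 23%
compound 3 `CCCCC1(C)C(=O)N(c2ccccc2)c2ncccc21`: 5%

In a functional assay on the whole organism (Pleural cavity) for inhibition, with Rattus norvegicus as the target, at a dose of 25 mg/kg (on this read-out lower numbers stand for less inhibition and higher numbers for more inhibition at the one dose given (going by the name of the read-out)), compound 3 stands lowest of the three, with compound 2 nearest and compound 1 furthest. Compound 4 `CC1C(=O)N(c2ccccc2)c2ncccc21` differs from compound 3 by hydrogen in place of butyl on a saturated ring carbon. Among the measured compounds shown here, no measured step removes a group from that ring carbon outright; the steps that bear on it are a number 48 percentage points lower from compound 1 to compound 3 (beyond the scatter) and a number 18 percentage points lower from compound 2 to compound 3 (beyond the scatter), both of which put butyl onto that carbon and both of which lowered the read-out. Taking butyl away again therefore points upward, but the size is uncertain, since hydrogen matches neither of the sulfur-bearing groups that were replaced. The account expects for compound 4 a modest rise, a number 20 percentage points higher from compound 3 to compound 4 (beyond the scatter). The estimate for compound 4 is 25%, ranging from 0% to 55%.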

Compound 4, a percentage reported as inhibition, in the whole organism at one dose (the size of the read-out at that dose, not a potency): 18%
Compound 4: the middle estimate sits 7 percentage points above what was measured; the range from low to high includes it.
By their numbers in this assay, from the lowest: compound 3; then compounds 4 and 2 (each within the scatter of the next); then compound 1.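

In this assay, hydrogen on this saturated ring carbon gives a baseline for the groups there: taking butyl away raises the read-out (a number 13 percentage points higher from compound 3 to compound 4 (beyond the scatter)), so butyl stands below hydrogen. Hydrogen in place of methylsulfanyl lowers it (a number 35 percentage points lower from compound 1 to compound 4 (beyond the scatter)), while hydrogen in place of (2-methoxyethyl)sulfanyl leaves it within the scatter (a number 5 percentage points lower from compound 2 to compound 4 (within the scatter)), so only methylsulfanyl stands clearly above hydrogen. Nothing available explains these differences.

Open, on these data alone, is whether ethylsulfanyl or methoxy on this carbon would match methylsulfanyl. An amine there also remains untested in the compounds shown.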